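A Larger Ring on the Ring Nitrogen: What to Expect

This account rests on a few compounds, and the source may have more. Where it says the series, first, only, none or still open, it means among the compounds named here.

Compound 1, `C[C@@H](O[C@@H]1CN(C(=O)C(C)(C)C)C[C@H]1c1ccccc1)c1cc(C(F)(F)F)cc(C(F)(F)F)c1`, gives 0.18 nM in an assay on CHO cells for displacement of a labelled ligand from Substance-P receptor (Homo sapiens); on this read-out higher numbers stand for weaker inhibition and lower numbers for stronger inhibition.
Compound 2, `C[C@@H](O[C@@H]1CN(C2=CC(=O)CC2)C[C@H]1c1ccccc1)c1cc(C(F)(F)F)cc(C(F)(F)F)c1`, gives 0.07 nM in this assay.

Of these two numbers, compound 2 carries the lower one, and the distance to compound 1 is beyond the scatter. Going by the values given here, the single step measured so far, a 2.6-fold lower number from compound 1 to compound 2 (0.41 log units; beyond the scatter), comes from putting 3-oxocyclopent-1-en-1-yl in place of (tert-butyl)carbonyl on the amine nitrogen in the ring of the shared core.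

Compound 3, `C[C@@H](O[C@@H]1CN(C2=CC(=O)C(C)(C)CC2)C[C@H]1c1ccccc1)c1cc(C(F)(F)F)cc(C(F)(F)F)c1`, has not yet been measured. Relative to compound 2 the change is 4,4-dimethyl-3-oxocyclohex-1-en-1-yl in place of 3-oxocyclopent-1-en-1-yl on an amine nitrogen in a ring. The measured step bears on it only loosely: it concerns a different exchange at the same nitrogen, and it shows that a new group there moved the number by a modest amount. Among the compounds with values here, no step that enlarges a ring or adds methyl groups has been measured, so there is nothing to point strongly in either direction. The expected step is therefore small, a 1.7-fold higher number from compound 2 to compound 3 (0.23 log units; within the scatter), and may well fall within the scatter. For compound 3 the estimate in this assay is 0.12 nM, with a range from 0.04 nM to 0.4 nM.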

Compound 3, half-maximal inhibitory concentration: 0.18 nM
Beside the measured number, compound 3's estimate is 1.5-fold (0.18 log units) below it; the measured number falls inside the stated range.
By their numbers in this assay, from the lowest: compound 2; then compounds 1 and 3 (each within the scatter of the next).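

In this assay, 4,4-dimethyl-3-oxocyclohex-1-en-1-yl in place of 3-oxocyclopent-1-en-1-yl gives a 2.6-fold higher number from compound 2 to compound 3 (0.41 log units; beyond the scatter), so two groups on this nitrogen that both hold a ring with a carbonyl can still read apart beyond the scatter. Against the other group at this position, the same new ring gives no change at the digits printed from compound 1 to compound 3 (within the scatter), which means a (tert-butyl)carbonyl and the six-membered ring cannot be told apart here, and among these three only compound 2 stands clear of the others. Nothing shown here offers a reason for these numbers.

The step from compound 2 to compound 3 enlarges the ring and adds the methyl groups at once, so the compounds shown cannot say which of the two changes goes with the higher number; the plain 3-oxocyclohex-1-en-1-yl group, without the methyl groups, would separate them. On these data alone, how this nitrogen would read with a group of another kind, such as an amine or a carboxylic acid on a short chain, also remains open.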